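Adding a fluoro group to compound 1

This account rests on a few compounds, and the source may have more. Where it says the series, first, only, none or still open, it means among the compounds named here.

Measured so far in an ADME assay on KB cells (Homo sapiens) for cytotoxicity; a lower number here means that less compound is needed, a higher number that more compound is needed for the effect
Compound 1 `COc1cc2c(c(OCc3ccccc3)c1OC)C(=O)[C@]1(OC)C=C[C@H]2N(C(=O)OCC(C)C)N1C(=O)OCC(C)C` gives 94 ug/mL
Compound 2 `CCOC(=O)N1[C@@H]2C=C[C@@](OC)(C(=O)c3c2cc(OC)c(OC)c3OCc2ccc(Cl)cc2)N1C(=O)OCC` gives 99.9 ug/mL

Compound 1 and compound 2 lie within the usual scatter of each other, so neither number stands apart from the other. Compound 3 `COc1cc2c(c(OCc3ccc(F)cc3)c1OC)C(=O)[C@]1(OC)C=C[C@H]2N(C(=O)OCC(C)C)N1C(=O)OCC(C)C` is still unmeasured. It matches compound 1 except for fluoro in place of hydrogen on an aromatic carbon as the change. A fluoro takes the place of hydrogen on an aromatic carbon, para to a large group, so benzyl becomes 4-fluorobenzyl. Among the compounds with values here, no two measured compounds differ in only one place, so the data give no direct guide to the size of this change. Within the data shown here, the only anchor is compound 1 at 94 ug/mL in this assay and so no shift beyond the scatter is expected. In numbers, the expected 1.0-fold lower number from compound 1 to compound 3 (0.02 log units; within the scatter) is a small one. The expected value for compound 3 is 90 ug/mL (45 ug/mL to 170 ug/mL).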

Compound 3, concentration for half-maximal effect: > 300 ug/mL
Compound 3: a limit, no number; the forecaster's own chance of this, stated with the estimate: 25%; middle value at least 3.3-fold (0.52 log units) from the limit.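

In this assay, replacing one hydrogen with fluoro, so that benzyl becomes 4-fluorobenzyl, gives an at least 3.1-fold higher number from compound 1 to compound 3 (0.50 log units; beyond the scatter). For compound 3 the reading is a limit of the assay, not a number: the limit of > 300 ug/mL in this assay, at which 1 of the 3 values shown sits. Within the data shown here, this single step shows what the earlier compounds could not: the aromatic carbon para to a large group is not a neutral place in this assay, since adding one fluorine atom there moves the result beyond the usual scatter.

From the compounds shown here alone, it remains open whether this shift is specific to fluoro, or whether a methoxy group or a nitrile at the same carbon would shift the number in the same way. Going by these compounds, it is also open whether fluoro on another carbon of this ring, or the same change on a compound that differs elsewhere from compound 1, would give a similar step.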